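A few compounds are considered here, and "the series" means these few. Any claim that something is new, unique, unknown or untested is made for them only; others in the source may bear on it.

Compound 1 `Nc1ncnc2c1nc(O)n2Cc1ccccc1`: 30 mg/kg
Compound 2 `CCc1nc(N)c2nc(O)n(Cc3ccccc3)c2n1`: 3 mg/kg

Among the compounds with values here, in a functional assay on the whole organism for activation, with Mus musculus as the target (a lower number here means that less compound is needed, a higher number that more compound is needed for the effect), compound 2 stands at the lower of the two numbers so far. Within the data shown here, the only measured step is a 10-fold lower number from compound 1 to compound 2 (1.00 log units; beyond the scatter), which came from putting ethyl in place of hydrogen on an aromatic carbon. Compound 3 `CCCCCSc1nc(N)c2nc(O)n(Cc3ccccc3)c2n1` has not yet been measured in this assay. It differs from compound 2 in one place: pentylsulfanyl in place of ethyl on an aromatic carbon. The carbon that carries the change is the same one that carried the ethyl group in compound 2, lying between two ring nitrogen atoms. Among the measured compounds shown here, the one measured step that touches this position shows that placing ethyl there instead of hydrogen gave a 10-fold lower number from compound 1 to compound 2 (1.00 log units; beyond the scatter). No measurement shows what a longer group, or one joined through sulfur, does at this carbon, so the direction of the next step is open. The most cautious expectation is that compound 3 stays near compound 2, with the step of no change at the digits printed from compound 2 to compound 3 (within the scatter) expected to lie within the scatter. Compound 3 is therefore estimated at 3 mg/kg, with a range from 1 mg/kg to 10 mg/kg.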

Compound 3, minimum effective dose: 1 mg/kg
The estimate for compound 3 lay 3.0-fold (0.48 log units) above the measured number; low and high end bracket the measured number.
By their numbers in this assay, from the lowest: compound 3; then compound 2; then compound 1.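

At the aromatic carbon between two ring nitrogen atoms, this assay now shows that ethyl does not mark the limit of what this position can give: pentylsulfanyl in place of ethyl brings a 3.0-fold lower number from compound 2 to compound 3 (0.48 log units; beyond the scatter). Set against plain hydrogen on the same carbon, the change is larger, a 30-fold lower number from compound 1 to compound 3 (1.48 log units; beyond the scatter), so across these three compounds the number falls from hydrogen to ethyl to pentylsulfanyl, and a longer chain joined through sulfur is accepted here. This step changes two things at once, the length of the chain and the sulfur link, and nothing else at hand speaks to the reason for the drop.

The compounds shown leave open which of those two changes matters, since a plain pentyl chain, a pentyloxy group or a pentylamino group on this carbon would be needed to separate the chain from the atom that joins it to the core. They also leave open how the number responds to chain length with the sulfur kept in place, as a shorter methylsulfanyl group or a longer octylsulfanyl group would show.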